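Isopropyl in Place of Phenyl: An Expected Loss

The source may report more compounds than this note shows. Statements on the series, on what has been measured and on what is new or still open speak of the compounds shown alone.

Among the measured compounds shown here, compound 1 `CC(C)n1nc(-c2cc(-c3ccccc3)on2)c2c(N)ncnc21` is the only compound with a number in an assay on BaF3 cells for inhibition of proto-oncogene tyrosine-protein kinase receptor Ret variant V804M (Homo sapiens), read by MTT assay, with a stated time of 48 h; a higher number here means a weaker inhibitor of growth, a lower number a stronger inhibitor of growth; in this assay compound 1 gives 4970 nM. Compound 2 `CC(C)n1nc(/C=N/O)c2c(N)ncnc21`, which lacks the phenyl altogether, reaches only a limit of the assay, > 10000 nM, so that (the limit of > 10000 nM in this assay, at which 1 of the 2 values shown sits). Compound 3 `CC(C)c1cc(-c2nn(C(C)C)c3ncnc(N)c23)no1` differs from compound 1 by isopropyl in place of phenyl on an aromatic carbon. For the measured compounds named here, no measured step between the two compounds is available, so compound 3 is expected to come out weaker, the step of a 1.8-fold higher number from compound 1 to compound 3 (0.26 log units; within the scatter) a modest loss beyond the scatter. Compound 3 is estimated at 9000 nM, within 3500 nM to 20000 nM.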

Compound 3, concentration for 50% growth inhibition: 5900 nM
Compound 3: middle estimate off by 1.5-fold (0.18 log units), on the high side; low and high end bracket the measured number.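

At this position, on an aromatic carbon next to the ring oxygen, isopropyl can stand in place of phenyl in this assay, with the step being a 1.2-fold higher number from compound 1 to compound 3 (0.07 log units; within the scatter). The six-membered aromatic ring is therefore not required to hold the level of growth inhibition that compound 1 reaches. Nothing shown gives a measured cause for this step.

As far as these compounds go, whether an amine, a carboxylic acid or a longer chain on this carbon would keep that level remains open. So does whether a substituted phenyl ring would give a lower number.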